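The source may hold more compounds than are shown below. What is called first, only, known or untested is meant among the compounds shown, and "the series" means these compounds.

Measured in a functional assay on MCF7 cells (Homo sapiens) for antiproliferative activity, read by MTT assay, with a stated time of 72 h; on this read-out lower numbers stand for stronger inhibition and higher numbers for weaker inhibition:
- Compound 1 `CC1=CC[C@H]2[C@@H]1CC=C(C)[C@@H](CC[C@H]1[C@]3(C)CC[C@H](O)C(C)(C)O[C@H]3CC[C@@]1(C)O)C2(C)C`: > 50000 nM (a limit, not a number)
- Compound 2 `CC1=CC[C@H]2[C@@H]1CC=C(C)[C@@H](CCC1=C(C)CC[C@@H]3OC(C)(C)[C@@H](O)CC[C@@]13C)C2(C)C`: > 50000 nM (a limit, not a number)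
- Compound 3 `CC(=O)O[C@H]1CC[C@]2(C)[C@H](CC[C@@](C)(O)[C@H]2CC[C@@H]2C(C)=CC[C@H]3[C@H](CC[C@]3(C)O)C2(C)C)OC1(C)C`: 47900 nM

Compound 3 is the only one of the three with an actual number, 47900 nM. Compound 1 and compound 2 stand at the limit of > 50000 nM in this assay, at which 2 of the 3 values shown sit.

The next compound to be tested is compound 4 `CC1=CC[C@H]2[C@H](CC[C@]2(C)O)C(C)(C)[C@@H]1CC[C@H]1[C@]2(C)CC[C@H](OC(=O)c3ccccc3)C(C)(C)O[C@H]2CC[C@@]1(C)O`, which departs from compound 3 by a single exchange: phenyl in place of methyl on a carbonyl carbon. This exchange turns acetoxy into benzoyloxy.

No measured step among these compounds shows what such an exchange does in this assay. Compound 3 at 47900 nM has little room on the weak side, so a modest move towards stronger inhibition is expected. A result at the limit remains possible. The expected change is a 1.9-fold lower number from compound 3 to compound 4 (0.28 log units; within the scatter). For compound 4 the estimated value is 25000 nM, with an expected range of 8000 nM to 60000 nM.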

Compound 4, half-maximal inhibitory concentration: 21000 nM
Compound 4: the middle estimate sits 1.2-fold (0.08 log units) above what was measured, and the stated range covers the measured number.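

With phenyl in place of methyl on a carbonyl carbon, turning acetoxy into benzoyloxy, this assay gives a 2.3-fold lower number from compound 3 to compound 4 (0.36 log units; beyond the scatter). This is the first readable step among the compounds shown, and it shows that the group on this carbonyl carbon can shift the read-out by a modest amount, although compound 4 still stands at 21000 nM. Steps involving the other two compounds cannot be read, as their values are limits and not numbers: the limit of > 50000 nM in this assay, at which 2 of the 4 values shown sit.

The compounds shown leave open whether the aromatic ring itself or simply the added carbon atoms account for the lower number. They also leave open what a longer chain, a benzoyl ring carrying an amine or a carboxylic acid, or a free hydroxyl at this place would do.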